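Removing the chloro from compound 2

This account rests on a few compounds, and the source may have more. Where it says the series, first, only, none or still open, it means among the compounds named here.

Measured so far in a functional assay on NCI-N87 cells (Homo sapiens) for antiproliferative activity, read by luminescence, with a stated time of 72 h; on this read-out lower numbers stand for stronger inhibition and higher numbers for weaker inhibition:
compound 1 `CN1CC=C(c2c(O)cc(O)c3c(=O)cc(-c4ccc(Sc5nc6ccccc6[nH]5)cc4)oc23)CC1`: 183 nM
compound 2 `CN1CC=C(c2c(O)cc(O)c3c(=O)cc(-c4ccc(Sc5nc6ccccc6n5C)cc4Cl)oc23)CC1`: 49 nM
compound 3 `CN1CC=C(c2c(O)cc(O)c3c(=O)cc(-c4ccc(Sc5nc6ccccc6[nH]5)cc4Cl)oc23)CC1`: 12 nM

Compound 2 stands in the middle of these three numbers at 49 nM, with compound 1 higher and compound 3 lower. The next structure, compound 4 `CN1CC=C(c2c(O)cc(O)c3c(=O)cc(-c4ccc(Sc5nc6ccccc6n5C)cc4)oc23)CC1`, differs from it by hydrogen in place of chloro on an aromatic carbon.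

The direct guide is the reverse exchange, a 15-fold lower number from compound 1 to compound 3 (1.18 log units; beyond the scatter), so losing the chloro should raise the number. Also relevant is a 4.1-fold lower number from compound 2 to compound 3 (0.61 log units; beyond the scatter), which is a smaller step. Compound 4 carries the same methyl on the aromatic nitrogen that separates compound 2 from compound 3, so it should also lie above compound 1 at 183 nM if that step carries over. Each exchange has been measured only once, and whether the two steps add is not known.

The expected change is a 12-fold higher number from compound 2 to compound 4 (1.09 log units; beyond the scatter) in this assay, a large step towards weaker inhibition. For compound 4 the estimated value is 600 nM with an expected range from 200 nM to 1800 nM on this read-out.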

Compound 4, half-maximal inhibitory concentration: 391 nM
The estimate for compound 4 lay 1.5-fold (0.19 log units) above the measured number; low and high end bracket the measured number.
By their numbers in this assay, from the lowest: compound 3; then compound 2; then compound 1; then compound 4.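

In this assay, hydrogen in place of chloro on the six-membered aromatic ring of carbon only gives an 8.0-fold higher number from compound 2 to compound 4 (0.90 log units; beyond the scatter), so the benefit of the chloro now appears with the methyl on the aromatic nitrogen as well as with hydrogen there: the same change on two cores in this assay, a 15-fold lower number (1.18 log units; beyond the scatter) from compound 1 to compound 3 and an 8.0-fold lower number (0.90 log units; beyond the scatter) from compound 4 to compound 2, 1.9-fold (0.28 log units) apart, within the scatter of two such steps. Methyl in place of hydrogen on the aromatic nitrogen, read without the chloro, gives a 2.1-fold higher number from compound 1 to compound 4 (0.33 log units; beyond the scatter), in the same direction as the step read with the chloro: the same change on two cores in this assay, a 4.1-fold lower number (0.61 log units; beyond the scatter) from compound 2 to compound 3 and a 2.1-fold lower number (0.33 log units; beyond the scatter) from compound 4 to compound 1, 1.9-fold (0.28 log units) apart, within the scatter of two such steps. With both exchanges now read on two cores, neither step's size differs beyond the scatter with the group at the other place.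

The compounds shown leave open whether this benefit is specific to chloro or would also come with fluoro, bromo or methoxy on this carbon. They also leave open how an ethyl group or a longer chain on the aromatic nitrogen would compare with methyl and hydrogen.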